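The source may hold more compounds than are shown below. What is called first, only, known or untested is meant among the compounds shown, and "the series" means these compounds.

Compound 2 `CC(C)(C)NC(=O)NCCS(=O)(=O)NC(=O)c1ccc(Nc2nc(NC3(c4ccc(Cl)cc4)CC3)nc(OCC(F)(F)F)n2)cc1` is the compound under comparison here. In a physicochemical assay for permeability, using PAMPA, at pH 7.4 (on this read-out higher numbers stand for higher permeability and lower numbers for lower permeability), compound 2 gives 49 nm/s, the highest of the three numbers measured. Compound 1 `CC(C)S(=O)(=O)NC(=O)c1ccc(Nc2nc(NC3(c4ccc(Cl)cc4)CC3)nc(OCC(F)(F)F)n2)cc1` stands nearest to it, with 31 nm/s in this assay, and the step of a 1.6-fold higher number from compound 1 to compound 2 (0.20 log units; within the scatter) lies within the scatter. Compound 3 `O=C(NS(=O)(=O)CCNC(=O)C1CC1)c1ccc(Nc2nc(NC3(c4ccc(Cl)cc4)CC3)nc(OCC(F)(F)F)n2)cc1` stands furthest away, with 1 nm/s in this assay, and the step of a 49-fold lower number from compound 2 to compound 3 (1.69 log units; beyond the scatter) is large and well beyond the scatter; the related step of a 31-fold lower number from compound 1 to compound 3 (1.49 log units; beyond the scatter) points the same way.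

Compound 4 `CNC(=O)NCCS(=O)(=O)NC(=O)c1ccc(Nc2nc(NC3(c4ccc(Cl)cc4)CC3)nc(OCC(F)(F)F)n2)cc1` differs from compound 2 in one place: methyl in place of tert-butyl on an amide-type nitrogen. The measured steps do not repeat this kind of change. The steps from compound 1 alter what sits on the sulfonyl sulfur, and the step from compound 2 to compound 3 swaps (tert-butyl)amino for cyclopropyl on a carbonyl carbon, which removes the whole urea-type arrangement rather than trimming the group on its nitrogen. There is therefore no direct guide, and only a modest step in this assay, in either direction or none beyond the scatter, is expected. The estimate for compound 4 in this assay is 25 nm/s, within a range from 6 nm/s to 70 nm/s, meaning an expected step of a 2.0-fold lower number from compound 2 to compound 4 (0.29 log units; within the scatter).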

Compound 4, apparent permeability: 40 nm/s
Beside the measured number, compound 4's estimate is 1.6-fold (0.20 log units) below it; the range from low to high includes it.
By their numbers in this assay, from the lowest: compound 3; then compounds 1, 4 and 2 (each within the scatter of the next).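

In this assay, methyl in place of tert-butyl on an amide-type nitrogen gives a 1.2-fold lower number from compound 2 to compound 4 (0.09 log units; within the scatter) and so leaves the number where it was, which shows that, for this pair, the tert-butyl is not needed to keep the read-out at this level. The earlier compounds shown here could not show this, since the step to compound 3 changed the whole urea-type arrangement at once; now methylamino in place of cyclopropyl on a carbonyl carbon gives a 40-fold higher number from compound 3 to compound 4 (1.60 log units; beyond the scatter) as a large step, so the gap between compound 3 and the urea-type compounds 2 and 4 does not rest on the tert-butyl group. For the compounds shown here, the longer side chain of compound 4 also stands level with the plain isopropyl on the sulfonyl sulfur, with 2-((methylcarbamoyl)amino)ethyl in its place giving a 1.3-fold higher number from compound 1 to compound 4 (0.11 log units; within the scatter) and compound 3 remaining the one low compound of the four.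

Going by these compounds, how the number would respond to a longer chain, a basic amine or a carboxylic acid on this nitrogen remains open. Nothing shown here explains why the cyclopropyl amide of compound 3 sits so far from the urea-type compounds.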